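A few compounds are considered here, and "the series" means these few. Any claim that something is new, unique, unknown or untested is made for them only; others in the source may bear on it.

Measured compounds:
- compound 1 `COc1ncc(-c2ccc3nc(NC(=O)NCC(=O)N4CCCC4)nn3c2)cc1NS(=O)(=O)c1ccc(F)cc1` — in a functional assay on A549 cells (Homo sapiens) for cytotoxicity, read by MTT assay, with a stated time of 72 h (on this read-out higher numbers stand for weaker inhibition and lower numbers for stronger inhibition), compound 1 gives 2190 nM
- compound 2 `CCN(CC)CCNC(=O)Nc1nc2ccc(-c3cnc(OC)c(NS(=O)(=O)c4ccc(C)cc4)c3)cn2n1` — compound 2 gives 730 nM
- compound 3 `CCN(CC)CCNC(=O)Nc1nc2ccc(-c3cnc(OC)c(NS(=O)(=O)c4ccc(F)cc4F)c3)cn2n1` — compound 3 gives 980 nM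

Compound 1 stands highest of the three numbers; compound 3 is nearest and compound 2 furthest, and both gaps lie beyond the scatter. Among the measured compounds shown here, compounds 2 and 3 differ from compound 1 in the urea side chain as well as in the group on the sulfonyl sulfur, so their values mark no single step against compound 1. For the measured compounds named here, the only measured step, a 1.3-fold higher number from compound 2 to compound 3 (0.13 log units; within the scatter), concerns the group on the sulfonyl sulfur and not the carbonyl side chain.

Compound 4 `COc1ncc(-c2ccc3nc(NC(=O)NCC(=O)N4CCOCC4)nn3c2)cc1NS(=O)(=O)c1ccc(F)cc1` follows compound 1 with one change: morpholin-4-yl in place of pyrrolidin-1-yl on a carbonyl carbon. Going by the values given here, no measured pair shows this change, so nothing bears on it directly. The expectation for the step is therefore a 1.0-fold higher number from compound 1 to compound 4 (0.00 log units; within the scatter), none beyond the scatter. Compound 4 is expected to give 2200 nM in this assay, with a range of 1000 nM to 4800 nM.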

Compound 4, half-maximal inhibitory concentration: 2570 nM
Compound 4: the middle estimate sits 1.2-fold (0.07 log units) below what was measured; the measured number falls inside the stated range.
By their numbers in this assay, from the lowest: compounds 2 and 3 (each within the scatter of the next); then compounds 1 and 4 (each within the scatter of the next).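

In this assay, among the compounds shown here, morpholin-4-yl in place of pyrrolidin-1-yl on a carbonyl carbon gives a 1.2-fold higher number from compound 1 to compound 4 (0.07 log units; within the scatter) and so provides the first measured step at this end of the side chain. The step lies within the scatter, so the two rings cannot be told apart here, although morpholin-4-yl brings one more heavy atom, an oxygen, and a hydrogen-bond acceptor. No measurement offered here accounts for this result.

The compounds shown leave open whether piperazine, an open-chain amine such as diethylamine, or a carboxylic acid in this place would give a number beyond the scatter. They also leave open whether this ring change reads the same with 4-methylphenyl or 2,4-difluorophenyl on the sulfonyl sulfur.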